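Ethyl for Methyl on the Aryl Group: Expecting Little

The source may hold more compounds than are shown below. What is called first, only, known or untested is meant among the compounds shown, and "the series" means these compounds.

Compound 1 `CC(C)n1ncc2c(C(=O)NCc3cn(-c4ccccc4)nn3)cccc21` and compound 2 `Cc1cccc(-n2cc(CNC(=O)c3cccc4c3cnn4C(C)C)nn2)c1` share one core and differ only in a methyl on an aromatic carbon. In a functional assay on PC-3 cells (Homo sapiens) for inhibition, read by MTT assay, with a stated time of 72 h (on this read-out lower numbers stand for stronger inhibition and higher numbers for weaker inhibition), compound 1 gives 26000 nM, and compound 2 gives 32300 nM. The step of a 1.2-fold higher number from compound 1 to compound 2 (0.09 log units; within the scatter) is too small to be trusted, so compound 2 stands alongside compound 1 rather than apart from it: the two cannot be told apart on these numbers.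

Compound 3 `CCc1ccc(-n2cc(CNC(=O)c3cccc4c3cnn4C(C)C)nn2)cc1` carries the next change: 4-ethylphenyl in place of 3-methylphenyl on an aromatic nitrogen. Within the data shown here, the only measured step that bears on this is a 1.2-fold higher number from compound 1 to compound 2 (0.09 log units; within the scatter), which also moved a small alkyl group on the same aromatic ring and stayed within the scatter. No step beyond the scatter is therefore expected in this assay. The estimate for compound 3 is 30000 nM, with a range from 12000 nM to 80000 nM. This means an expected step of a 1.1-fold lower number from compound 2 to compound 3 (0.03 log units; within the scatter).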

Compound 3, half-maximal inhibitory concentration: 26600 nM
Beside the measured number, compound 3's estimate is 1.1-fold (0.05 log units) above it; measured number inside the range.
By their numbers in this assay, from the lowest: compounds 1, 3 and 2 (each within the scatter of the next).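

Replacing 3-methylphenyl with 4-ethylphenyl on the aromatic nitrogen gives no readable difference in this assay (the step is a 1.2-fold lower number from compound 2 to compound 3 (0.08 log units; within the scatter)). Compound 3 also cannot be told apart from the plain phenyl group of compound 1 (a 1.0-fold higher number from compound 1 to compound 3 (0.01 log units; within the scatter)), so an ethyl group now joins the methyl group in leaving the result within the scatter. Nothing available here explains why these groups make so little difference.

The compounds shown carry only methyl or ethyl on this aromatic ring, so they test a narrow range of changes at this position. Going by these compounds, whether an amine, a carboxylic acid or a longer chain on the same ring would give a step beyond the scatter remains open.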